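Oxan-4-yl on the sulfonamide nitrogen: working notes

This account rests on a few compounds, and the source may have more. Where it says the series, first, only, none or still open, it means among the compounds named here.

Values in an ADME assay on microsomes from liver (Mus musculus) for metabolic stability, tested at 5 uM (a lower number here means that the compound disappears faster, a higher number that the compound lasts longer), follow, each one a limit and not a number:
- Compound 1 `O=C(O)c1ccc(NCCCCCCCC(F)(F)F)c(S(=O)(=O)N2CCCCC2)c1` gives > 1 h as its value
- Compound 2 `O=C(O)c1ccc(NCCCCCCCC(F)(F)F)c(S(=O)(=O)NC2CCCC2)c1` gives > 1 h as its value
- Compound 3 `O=C(O)c1ccc(NCCCCCCCC(F)(F)F)c(S(=O)(=O)NC2CCCCC2)c1` gives > 1 h as its value
- Compound 4 `O=C(O)c1ccc(NCCCCCCCC(F)(F)F)c(S(=O)(=O)NC2CCOCC2)c1` has not yet been measured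

Compound 3 is known only through the limit > 1 h and has no number. The series stands at the limit of > 1 h in this assay, at which 3 of the 3 values shown sit, and no order among its members can be read.

The next change is oxan-4-yl in place of cyclohexyl on a sulfonamide nitrogen and reads in words as oxan-4-yl in place of cyclohexyl on a sulfonamide nitrogen. The closest measured change at that place is a step that the two limits leave unreadable from compound 2 to compound 3 and the other two are a step that the two limits leave unreadable from compound 1 to compound 2 and a step that the two limits leave unreadable from compound 1 to compound 3 in the same series. None of these steps has a readable size, and none brings in oxan-4-yl, so they set no size for this change and no direction.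

The expected outcome in this assay is a step that the limit leaves unreadable from compound 3 to compound 4 with nothing foreseen beyond the scatter. For compound 4 the estimated half-life is 1.5 h with an expected range from 0.7 h to 4 h and another report of only a limit is expected as the likeliest result.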

Compound 4, half-life in the Mus musculus assay: > 1 h
Compound 4 ended at the assay's limit (the forecaster's own chance of this, stated with the estimate: 70%); the middle value does not contradict the limit.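

In the Mus musculus assay compound 4 gives > 1 h, a limit and not a number. Going by these compounds alone, no step among compound 1, compound 2, compound 3 and compound 4 can be read from these limits. In a physicochemical assay for solubility, in phosphate buffer, measured as kinetic solubility, at pH 7.4, tested at 250 uM (on this read-out lower numbers stand for lower solubility and higher numbers for higher solubility), compound 3 gives 9000 nM and compound 4 gives 244000 nM. What stays open is how far the half-lives of these compounds actually run, and whether, in the physicochemical assay, a 27-fold higher number from compound 3 to compound 4 (1.43 log units; beyond the scatter) comes with any difference in half-life.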